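Aryl swap on the benzyl group of compound 2

The source may hold more compounds than are shown below. What is called first, only, known or untested is meant among the compounds shown, and "the series" means these compounds.

Measured compounds:
compound 1 `CC(C)(C)c1cc(/C=C/C(=O)NCCC2CCN(Cc3ccccc3F)CC2)cc(C(C)(C)C)c1O`: 60200 nM
compound 2 `CC(C)(C)c1cc(/C=C/C(=O)NCCC2CCN(Cc3cccc([N+](=O)[O-])c3)CC2)cc(C(C)(C)C)c1O`: 70900 nM

Of the compounds shown here, two have so far been measured in an assay on isolated protein for inhibition of Amine oxidase [flavin-containing] A (Homo sapiens), read by fluorescence, with stated times of 15 min and 20 min; a lower number here means a stronger inhibitor, a higher number a weaker inhibitor. In this assay compound 1 gives 60200 nM, and compound 2 gives 70900 nM. Going by the values given here, compound 2 carries the higher of the two numbers, but its only neighbour is compound 1, and the step of a 1.2-fold higher number from compound 1 to compound 2 (0.07 log units; within the scatter) means the two cannot be told apart.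

Compound 3 `CC(C)(C)c1cc(/C=C/C(=O)NCCC2CCN(Cc3ccc(C#N)cc3)CC2)cc(C(C)(C)C)c1O` is the next member. Relative to compound 2 the change is 4-cyanophenyl in place of 3-nitrophenyl on a saturated chain carbon bound to an amine nitrogen in a ring. Among the compounds with values here, the one measured step that bears on this is the step from compound 1 to compound 2, which also exchanges the aryl group on that same saturated chain carbon and produced a 1.2-fold higher number from compound 1 to compound 2 (0.07 log units; within the scatter). That single step is the whole record for this part of the molecule, and it showed nothing beyond the scatter. Compound 3 is therefore expected to change by a 1.1-fold lower number from compound 2 to compound 3 (0.04 log units; within the scatter), that is, no step beyond the scatter. The estimate for compound 3 in this assay is 65000 nM, with a range of 25000 nM to 170000 nM.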

Compound 3, half-maximal inhibitory concentration: 78200 nM
Estimate against measurement, compound 3: 1.2-fold (0.08 log units) below; the measured number falls inside the stated range.
By their numbers in this assay, from the lowest: compounds 1, 2 and 3 (each within the scatter of the next).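

Exchanging 3-nitrophenyl for 4-cyanophenyl on the saturated chain carbon bound to an amine nitrogen in a ring gives a 1.1-fold higher number from compound 2 to compound 3 (0.04 log units; within the scatter) in this assay, and exchanging 2-fluorophenyl for 4-cyanophenyl gives a 1.3-fold higher number from compound 1 to compound 3 (0.11 log units; within the scatter). Where the earlier record held a single exchange at this place, there are now three aryl groups, 2-fluorophenyl, 3-nitrophenyl and 4-cyanophenyl, and all three pairs lie within the scatter, so none of these exchanges can be told apart from no change at all. Nothing measured here offers an explanation for this lack of separation.

The compounds shown leave open whether any group at this place can move the number beyond the scatter, for example an unsubstituted phenyl, a phenyl carrying a carboxylic acid or an amine, or a longer chain in place of the benzyl group. They also leave open whether the same exchanges would remain within the scatter on a compound that differs elsewhere from the shared core, or on one with a stronger number in this assay.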